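The source may report more compounds than this note shows. Statements on the series, on what has been measured and on what is new or still open speak of the compounds shown alone.

In an assay on CHO cells for displacement of a labelled ligand from C-X-C chemokine receptor type 4 (Homo sapiens), with a stated time of 40 min (on this read-out lower numbers stand for stronger inhibition and higher numbers for weaker inhibition), three compounds have been measured:

Compound 1 `c1c(CNCCCNC2CCCCC2)cc(CNCCCNC2CCCCC2)cc1CNCCCNC1CCCCC1`: 312 nM
Compound 2 `O=[N+]([O-])c1cc(CNCCCNC2CCCCC2)ccc1CNCCCNC1CCCCC1`: 354 nM
Compound 3 `Nc1cc(CNCCCNC2CCCCC2)ccc1CNCCCNC1CCCCC1`: 68.9 nM

Compound 3 stands lowest of the three numbers in this assay; its nearest neighbour is compound 1, with a higher number, and the furthest is compound 2, whose number is higher still. The one single-point step among these compounds runs from the nitro compound to the amino compound: a 5.1-fold lower number from compound 2 to compound 3 (0.71 log units; beyond the scatter).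

Compound 4 `CN(C)c1cc(CNCCCNC2CCCCC2)ccc1CNCCCNC1CCCCC1` differs from compound 3 in one place: dimethylamino in place of amino on an aromatic carbon. For the measured compounds named here, no measured step bears directly on this change; the step from compound 2 to compound 3 concerns the same position but a different pair of groups, and it shows only that exchanging the group there can move the number beyond the scatter in either direction. With nothing to point to a larger shift, a step of modest size is expected, most likely upward, as a 1.7-fold higher number from compound 3 to compound 4 (0.24 log units; within the scatter). Compound 4 is therefore estimated at 120 nM in this assay, within a range from 40 nM to 400 nM.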

Compound 4, half-maximal inhibitory concentration: 48 nM
Beside the measured number, compound 4's estimate is 2.5-fold (0.40 log units) above it, and the stated range covers the measured number.
By their numbers in this assay, from the lowest: compounds 4 and 3 (each within the scatter of the next); then compounds 1 and 2 (each within the scatter of the next).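

Exchanging amino for dimethylamino on this aromatic carbon gives a 1.4-fold lower number from compound 3 to compound 4 (0.16 log units; within the scatter) in this assay, so the amino group's hydrogen-bond donor can go and two further carbons can come in at this place without moving the number beyond the scatter. The gap from the nitro compound is confirmed by a second group, with a 7.4-fold lower number from compound 2 to compound 4 (0.87 log units; beyond the scatter), so compound 3 and compound 4 both stand apart from compound 2, and the earlier step from nitro to amino was not peculiar to the unsubstituted amino group. Nothing measured here says what lies behind these numbers.

The compounds shown leave open how far substitution on this nitrogen can go, as with diethylamino or a pyrrolidine. They also leave open whether a methoxy or a hydroxyl group at this place would stand with the two amines or with the nitro compound.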